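Piperidine for methylpiperazine on the anilino ring of the series

The compounds below may be only part of what the source reports. "The series", "measured", "known", "first", "only" and "open" are said of these compounds alone.

Measured compounds:
compound 1 `CN1CCN(c2ccc(Nc3ncc4c(n3)N(C3CCCC3)CC(=O)N4C)nc2)CC1` — 13100 nM
compound 2 `CN1C(=O)CN(C2CCCC2)c2nc(Nc3ccc(N4CCCCC4)cn3)ncc21` — > 30000 nM
compound 3 `CCN1C(=O)CN(C2CCCC2)c2nc(Nc3ccc(N4CCN(C)CC4)cc3)ncc21` — 28300 nM

In a functional assay on HeLa cells (Homo sapiens) for inhibition, read by MTT assay, with a stated time of 48 h (a lower number here means a stronger inhibitor, a higher number a weaker inhibitor), compound 1 gives 13100 nM. Compound 2 reaches only a limit of the assay, > 30000 nM, in this assay. The pair is separated by one change, (piperidin-1-yl in place of 4-methylpiperazin-1-yl on an aromatic carbon), and the step is an at least 2.2-fold higher number from compound 1 to compound 2 (0.35 log units; beyond the scatter); its size is known only as a floor because of the limit of > 30000 nM in this assay, at which 1 of the 3 values shown sits.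

Compound 3 gives 28300 nM in this assay, a higher number than compound 1 by a margin beyond the scatter; the difference between the two cores is not broken down here.

Compound 4 `CCN1C(=O)CN(C2CCCC2)c2nc(Nc3ccc(N4CCCCC4)cc3)ncc21` is still to be measured. It differs from compound 3 by piperidin-1-yl in place of 4-methylpiperazin-1-yl on an aromatic carbon. This is the same kind of change as that from compound 1 to compound 2, though not the same: there the place is on a six-membered aromatic ring with 1 nitrogen, two atoms from the ring nitrogen, whereas here it is on a six-membered aromatic ring of carbon only, in both cases para to a large group.

Given that compound 3 already stands at 28300 nM, and that the same kind of change gave an at least 2.2-fold higher number from compound 1 to compound 2 (0.35 log units; beyond the scatter), compound 4 is expected to move by a 2.1-fold higher number from compound 3 to compound 4 (0.33 log units; beyond the scatter) in this assay. Compound 4 is therefore estimated at 60000 nM in this assay, in the range 25000 nM to 150000 nM, and it is expected that the assay may well return only a limit for it.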

Compound 4, half-maximal inhibitory concentration: > 30000 nM
Compound 4 was reported as a limit; the forecaster's own chance of this, stated with the estimate: 70%; the middle value lies beyond the limit too.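

In this assay compound 4 is reported only as a limit of the assay, > 30000 nM. Piperidin-1-yl in place of 4-methylpiperazin-1-yl on the ring of carbon only gives an at least 1.0-fold higher number from compound 3 to compound 4 (0.02 log units; that floor lies within the scatter), and this floor does not by itself establish a real rise on this core, so the two steps can be set side by side only with that reservation: the same change on two cores in this assay, an at least 2.2-fold higher number (0.35 log units; beyond the scatter) from compound 1 to compound 2 and an at least 1.0-fold higher number (0.02 log units; that floor lies within the scatter) from compound 3 to compound 4; the limit leaves it open whether they differ The series therefore shows no lower number with piperidin-1-yl on either core, but it does not show that the change carries over from one core to the other with the same size, and the true size of each step remains unread: the limit of > 30000 nM in this assay, at which 2 of the 4 values shown sit.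

The compounds shown leave open whether a morpholin-4-yl group or an open-chain dimethylamino group in this place would give a number that can be read within the range of this assay. Also open, from the compounds shown here alone, is how much of the gap between the values of the two 4-methylpiperazin-1-yl compounds belongs to each difference between their cores, as those cores differ in more than one place.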